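A few compounds are considered here, and "the series" means these few. Any claim that something is new, unique, unknown or untested is made for them only; others in the source may bear on it.

Measured compounds:
- compound 1, `CC(=O)c1ccc(NC(=O)C(C(C)C)N(C(=O)c2ccccc2)S(=O)(=O)c2ccc(C)cc2)cc1`, in a functional assay, read by spectrophotometry, with a stated time of 20 min (a lower number here means a stronger inhibitor, a higher number a weaker inhibitor), compound 1 gives 12000000 nM
- compound 2, `CCC(C)C(C(=O)Nc1ccc(C(C)=O)cc1)N(C(=O)c1ccccc1)S(=O)(=O)c1ccc([N+](=O)[O-])cc1`, in this assay compound 2 gives 50000000 nM

For the measured compounds named here, compound 2 holds the higher of the two numbers measured so far; the only neighbour, compound 1, sits lower by a gap that goes beyond the scatter of this assay. Going by the values given here, the two differ in two places at once, so no single-change step between measured compounds exists.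

Compound 3, `CC(=O)c1ccc(NC(=O)C(C(C)C)N(C(=O)c2ccccc2)S(=O)(=O)c2ccc([N+](=O)[O-])cc2)cc1`, is the next compound to be measured. It differs from compound 2 by hydrogen in place of methyl on a saturated chain carbon, three bonds along the chain from an amide-type nitrogen and a carbonyl carbon, that is, sec-butyl to isopropyl, with the rest of the structure kept. This brings the chain to the form found in compound 1, while the remaining part of compound 3 stays as in compound 2. The gap between compound 2 and compound 1 in this assay cannot be split between the two changes, so the direction for compound 3 is uncertain. A modest move toward a lower number is expected, and the step of a 2.0-fold lower number from compound 2 to compound 3 (0.30 log units; within the scatter) is the estimate here. Compound 3 is thus expected to give 25000000 nM, with a range from 8000000 nM to 80000000 nM.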

Compound 3, half-maximal inhibitory concentration: 6800000 nM
Compound 3: the middle estimate sits 3.7-fold (0.57 log units) above what was measured; measured number outside the range, below it.
By their numbers in this assay, from the lowest: compounds 3 and 1 (each within the scatter of the next); then compound 2.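

In this assay, for the compounds shown here, the exchange of sec-butyl for isopropyl, with hydrogen in place of methyl on a saturated chain carbon, gives a 7.4-fold lower number from compound 2 to compound 3 (0.87 log units; beyond the scatter) and is the first single-change step read at this chain, showing that the loss of one methyl alone moves the number beyond the scatter. The other new step, nitro in place of methyl on an aromatic carbon, is a 1.8-fold lower number from compound 1 to compound 3 (0.25 log units; within the scatter) and stays within the scatter, so this exchange shows no readable change with the isopropyl chain in place; of the two changes that separate compound 1 and compound 2, only the chain change has a step beyond the scatter. Nothing measured here gives a reason for the size of the chain step.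

The compounds shown leave open how the number would respond if this chain were cut further to ethyl or methyl, lengthened to n-butyl, or closed into a cyclohexyl ring. They also leave open whether an amine or a carboxylic acid in place of the nitro group would give a step beyond the scatter.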